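This account rests on a few compounds, and the source may have more. Where it says the series, first, only, none or still open, it means among the compounds named here.

Compound 1 `COc1cc(OCc2csc(-c3cccc(C(=O)N(C)C)c3)n2)c2cc(-c3cn4nc(OC)sc4n3)oc2c1` is the reference point of this set. Among the measured compounds shown here, in a functional assay on HEK293 cells for antagonist activity at proteinase-activated receptor 4 (Homo sapiens), read by FLIPR and calcium flux, with a stated time of 30 min (on this read-out higher numbers stand for weaker inhibition and lower numbers for stronger inhibition), compound 1 gives 0.8 nM, and it is the only compound here with a number to its name, so it stands alone rather than ranked against anything. A second member of the series, compound 2 `COc1cc(OCc2cccc(-c3ccc(C#N)cc3)c2)c2cc(-c3cn4nc(OC)sc4n3)oc2c1`, was assembled around the same core but carries no result in this assay; for compound 2 the entry reads "nd" (no result reported), so nothing can be said about where it falls.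

The compound still to be measured is compound 3 `COc1cc(OCc2csc(N3CCOCC3=O)n2)c2cc(-c3cn4nc(OC)sc4n3)oc2c1`, which keeps the core of compound 1 and changes one place: 3-oxomorpholin-4-yl in place of 3-(dimethylcarbamoyl)phenyl on an aromatic carbon. For the measured compounds named here, no pair of measured compounds in this set differs in a single place, so there is no measured step to compare this change against. The group that leaves is the larger of the two, and the group that enters is a 3-oxomorpholin-4-yl. On that basis compound 3 is expected to inhibit less strongly than compound 1, with a step from compound 1 to compound 3 of a 15-fold higher number from compound 1 to compound 3 (1.18 log units; beyond the scatter), a shift taken to lie beyond the usual scatter. In this assay compound 3 is therefore estimated at 12 nM, with a likely range from 2 nM to 80 nM.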

Compound 3, half-maximal inhibitory concentration: 1.7 nM
Beside the measured number, compound 3's estimate is 7.1-fold (0.85 log units) above it; the whole stated range lies above it.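

In this assay, putting 3-oxomorpholin-4-yl in place of 3-(dimethylcarbamoyl)phenyl gives a 2.1-fold higher number from compound 1 to compound 3 (0.33 log units; beyond the scatter) and counts as a modest step. The position on the aromatic carbon of the five-membered aromatic ring with 1 nitrogen and 1 sulfur therefore accepts a smaller, non-aromatic ring, and a six-membered aromatic ring of carbon only is not needed there for a low number, as compound 3 still reads 1.7 nM on this scale. Nothing shown here bears on what lies behind this small loss, so the step stands as an observation only.

What the compounds shown leave open is whether the carbonyl of the 3-oxomorpholin-4-yl group matters at this position, a question that a plain morpholine or a piperazine on the same carbon would address. On these data alone, it is also open how far the position accepts other kinds of group, such as an open-chain amine or a carboxylic acid, since a single step from one reference compound cannot define its limits.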